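The compounds below may be only part of what the source reports. "The series", "measured", "known", "first", "only" and "open" are said of these compounds alone.

Measured so far: compound 1 `Cc1cc(N2CCNCC2)nc(SCc2nc3ccccc3[nH]2)n1`, compound 2 `Cc1cc(Nc2cccc(C(F)(F)F)c2)nc(SCc2nc3ccccc3[nH]2)n1`, compound 3 `Cc1cc(Nc2ccc(F)cc2)nc(SCc2nc3ccccc3[nH]2)n1`.

In a functional assay on ECa-109 cells (Homo sapiens) for cytotoxicity, read by MTT assay, with a stated time of 72 h (a higher number here means a weaker inhibitor, a lower number a stronger inhibitor), compound 1 gives only a limit, > 100000 nM. Compound 2 likewise gives only a limit, > 100000 nM. Compound 3 gives 69500 nM. Compound 1 thus stands at the limit of > 100000 nM in this assay, at which 2 of the 3 values shown sit, with no number of its own. For the measured compounds named here, the only measured step from it, (4-fluorophenyl)amino in place of piperazin-1-yl on an aromatic carbon, gave an at least 1.4-fold lower number from compound 1 to compound 3 (0.15 log units; that floor lies within the scatter). Compound 4 `Cc1cc(NC(C)C)nc(SCc2nc3ccccc3[nH]2)n1` differs from compound 1 by isopropylamino in place of piperazin-1-yl on an aromatic carbon. Going by the values given here, no measured step puts isopropylamino in at that aromatic carbon, so only the step from compound 1 to compound 3 bears on it, and it stayed within the scatter. No step beyond the scatter is therefore expected in this assay. Compound 4 is estimated at 100000 nM, between 40000 nM and 300000 nM, an expected step of a number no higher from compound 1 to compound 4 (the limit leaves the size open).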

Compound 4, half-maximal inhibitory concentration: > 100000 nM
Compound 4: only a limit was reported; the forecaster's own chance of this, stated with the estimate: 60%; the middle value lies on the limit itself.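

With isopropylamino at this aromatic carbon, the series gains a small open-chain amine alongside piperazin-1-yl in this assay, but the step between these two groups cannot be read, as both values are limits. Replacing the 4-fluorophenyl on the nitrogen with isopropyl gives an at least 1.4-fold higher number from compound 3 to compound 4 (0.15 log units; that floor lies within the scatter). The open-chain amine thus joins the cyclic one at the ceiling of the assay: the limit of > 100000 nM in this assay, at which 3 of the 4 values shown sit.

As far as these compounds go, whether a longer alkylamino chain, a morpholine ring or a benzylamino group at this carbon would give a readable value in this assay stays open.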